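Series notes: acetyl removal and the cytotoxicity read-out

This account rests on a few compounds, and the source may have more. Where it says the series, first, only, none or still open, it means among the compounds named here.

Compound 1 `C=C1CC[C@@H]2[C@](C)(CO)[C@H](O)CC[C@@]2(C)[C@@H]1C/C=C1/C(=O)OC[C@H]1Oc1cccnc1[N+](=O)[O-]` in an ADME assay on SNB-19 cells (Homo sapiens) for cytotoxicity, read by MTT assay, with a stated time of 24 h (on this read-out higher numbers stand for lower toxicity in this test and lower numbers for higher toxicity in this test), gives 67700 nM. Compound 2 `C=C1CC[C@@H]2[C@](C)(CO)[C@H](O)CC[C@@]2(C)[C@@H]1C/C=C1/C(=O)OC[C@@H]1Oc1cccc2ccc(C)nc12` in this assay reaches only the limit of the assay, > 100000 nM, and not a number. Compound 3 `C=C1CC[C@@H]2[C@](C)(COC(C)=O)[C@H](O)CC[C@@]2(C)[C@@H]1C/C=C1/C(=O)OC[C@H]1Oc1cccc2ccc(C)nc12` in this assay likewise reports only a limit, > 100000 nM, not a number. Compound 3 therefore stands at the limit of > 100000 nM in this assay, at which 2 of the 3 values shown sit; no ordering of compound 3 against compound 2 can be drawn from what is shown, and only compound 1 has a measured number in this series.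

Compound 4 `C=C1CC[C@@H]2[C@](C)(CO)[C@H](O)CC[C@@]2(C)[C@@H]1C/C=C1/C(=O)OC[C@H]1Oc1cccc2ccc(C)nc12` carries hydrogen in place of acetyl on an oxygen on a saturated carbon, that is, hydrogen in place of acetyl on an oxygen on a saturated carbon, read one bond further out as acetoxymethyl to hydroxymethyl. Going by the values given here, no measured pair isolates this change on its own. In this assay the expected step is a step that the limit leaves unreadable from compound 3 to compound 4, none beyond the scatter. Compound 4 is accordingly expected to sit around 150000 nM, within 60000 nM to 400000 nM, and is expected most often to come back as a limit rather than a number.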

Compound 4, half-maximal cytotoxic concentration: > 100000 nM
Compound 4 ended at the assay's limit; the forecaster's own chance of this, stated with the estimate: 75%; the middle value is on the limit's open side.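

Compound 4 also sits at the limit, so the change from acetoxymethyl to hydroxymethyl yields no number in this assay: the limit of > 100000 nM in this assay, at which 3 of the 4 values shown sit. The steps to compound 4 from compound 3 and from compound 2 cannot be read, and the pair with compound 2 adds a comparison of configuration alone: the fact that compounds 2 and 4 differ only in the configuration as drawn. With 2-methylquinolin-8-yl in place of 2-nitropyridin-3-yl on the oxygen, the series now has one pair with a partly readable step, an at least 1.4-fold higher number from compound 1 to compound 4 (0.16 log units; that floor lies within the scatter), so this pair separates the two groups by no more than a floor within the scatter.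

Going by these compounds, whether acetoxymethyl, hydroxymethyl or either configuration differ at all remains open while these compounds stay at the limit. An amine or a carboxylic acid in place of the hydroxymethyl would show whether this position can bring the read-out to a number.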